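Succinimide piperazine amides in the maximal electroshock model

A few compounds are considered here, and "the series" means these few. Any claim that something is new, unique, unknown or untested is made for them only; others in the source may bear on it.

Measured so far:
compound 1, `CC(C(=O)N1CCN(c2ccc(Cl)cc2)CC1)N1C(=O)CCC1=O`, 50%
compound 2, `CCC(C(=O)N1CCN(c2cccc(C)c2)CC1)N1C(=O)CCC1=O`, 50%

In a functional assay on the whole organism (strain Swiss) with Mus musculus as the target, in the maximal electroshock model, with a stated time of 0.25 h, at a dose of 100 mg/kg by the intraperitoneal route (on this read-out higher numbers stand for a stronger effect at the one dose given and lower numbers for a weaker effect), compound 2 gives 50%, level with compound 1 at the digits shown; the two values lie within the scatter of each other, so no order between them can be read. Compound 3, `Cc1cccc(N2CCN(C(=O)C(C)N3C(=O)CCC3=O)CC2)c1`, differs from compound 2 by hydrogen in place of methyl on a saturated chain carbon, two bonds along the chain from an amide-type nitrogen in a ring and a carbonyl carbon. For the measured compounds named here, no step between two measured compounds isolates this change, and the two values in hand are alike. The step from compound 2 to compound 3 is therefore expected to be none beyond the scatter, no change at the digits printed from compound 2 to compound 3 (within the scatter). For compound 3 an activity of 50% is estimated, in the range 25% to 75%.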

Compound 3, a percentage reported as activity, at one dose (the size of the read-out at that dose, not a potency): 0%
For compound 3 the middle estimate is 50 percentage points above the measured one; measured number below the stated range.
By their numbers in this assay, from the lowest: compound 3; then compounds 1 and 2 (each within the scatter of the next).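

Hydrogen in place of methyl on a saturated chain carbon, two bonds along the chain from an amide-type nitrogen in a ring and a carbonyl carbon, gives a number 50 percentage points lower from compound 2 to compound 3 (beyond the scatter) in this assay and so shows that this position is not indifferent. With that chain unchanged, 3-methylphenyl in place of 4-chlorophenyl on an amine nitrogen in a ring gives a number 50 percentage points lower from compound 1 to compound 3 (beyond the scatter) and so shows that the aryl group counts as well. Nothing available explains either step.

Still open, from the compounds shown here alone, is whether a longer chain such as propyl at that carbon would hold the read-out. Also open, going by these compounds, is how 4-chlorophenyl behaves with ethyl at that carbon.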